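The source may report more compounds than this note shows. Statements on the series, on what has been measured and on what is new or still open speak of the compounds shown alone.

Measured so far:
- compound 1 `CN(C)c1cccc(C2=NC(c3ccc(F)cc3)(c3ccc(F)cc3)CN2)c1`: in an assay on LM cells for displacement of a labelled ligand from Neuropeptide Y receptor type 5 (Homo sapiens) (on this read-out lower numbers stand for stronger inhibition and higher numbers for weaker inhibition), compound 1 gives > 1000 nM, which is a limit of the assay and not a number (the limit of > 1000 nM in this assay, at which 1 of the 2 values shown sits).
- compound 2 `Fc1ccc(C2(c3ccc(F)cc3)CNC(c3ccsc3)=N2)cc1`: in this assay compound 2 gives 93 nM.

Going by the values given here, compound 2 therefore holds the only actual number in this assay; the other value shown is a limit. Compound 3 `Fc1ccc(C2(c3ccc(F)cc3)CNC(c3cccs3)=N2)cc1` differs from compound 2 by a single change: thiophen-2-yl in place of thiophen-3-yl on a carbon with a double bond to nitrogen.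

Among the compounds with values here, only one measured step is available for comparison, and it concerns the same position on the shared core: the step of an at least 10-fold lower number from compound 1 to compound 2 (1.03 log units; beyond the scatter), where a 3-(dimethylamino)phenyl group gave way to thiophen-3-yl. That step swapped one group for a quite different one. The change from compound 2 to compound 3 is much smaller, keeping the same atoms and merely joining the thiophene ring at a different carbon. On that basis no step beyond the scatter is expected in this assay.

Compound 3 is therefore estimated at 100 nM, with a likely range from 30 nM to 350 nM. This corresponds to an expected step of a 1.1-fold higher number from compound 2 to compound 3 (0.03 log units; within the scatter), essentially unchanged.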

Compound 3, half-maximal inhibitory concentration: 54 nM
Estimate against measurement, compound 3: 1.9-fold (0.27 log units) above, and the stated range covers the measured number.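

Joining the thiophene ring through a different carbon gives, in this assay, a 1.7-fold lower number from compound 2 to compound 3 (0.24 log units; within the scatter), so this assay does not tell thiophen-2-yl and thiophen-3-yl apart at the carbon between the two ring nitrogen atoms. The large drop seen earlier is therefore not tied to one attachment point, since replacing the 3-(dimethylamino)phenyl group with the other thiophene also gives an at least 18-fold lower number from compound 1 to compound 3 (1.26 log units; beyond the scatter). That step has only one measured end, and compound 1 gives a limit of the assay and not a number: the limit of > 1000 nM in this assay, at which 1 of the 3 values shown sits.

The compounds shown leave open whether the lower numbers come from having a thiophene ring or simply from losing the 3-(dimethylamino)phenyl group, a question that an unsubstituted phenyl or a furan-2-yl at this carbon could help to settle. As far as these compounds go, the two 4-fluorophenyl groups are also the same in all three compounds, so what happens with chlorine or a methoxy group in place of their fluorine remains unknown.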